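Sulfamate series: amine substituent change from compound 3 to compound 4

A few compounds are considered here, and "the series" means these few. Any claim that something is new, unique, unknown or untested is made for them only; others in the source may bear on it.

Measured compounds:
compound 1, `NS(=O)(=O)Oc1ccc2c(c1)CN(C(=O)c1cccc(N3CCC(N4CCCCC4)CC3)c1)CC2`: 0%
compound 2, `CCN(Cc1ccccc1)c1ccc(C(=O)N2CCc3ccc(OS(N)(=O)=O)cc3C2)cc1`: 66.9%
compound 3, `CN(CCCN1CCCCC1)c1cccc(C(=O)N2CCc3ccc(OS(N)(=O)=O)cc3C2)c1`: 24.1%

In an assay on HEK293 cells for inhibition of Steryl-sulfatase (Homo sapiens), tested at 0.1 uM (a lower number here means a weaker effect, a higher number a stronger effect of the compound at the concentration tested), compound 1 gives 0%, compound 2 gives 66.9% and compound 3 gives 24.1%. Compound 3 stands second highest of the three numbers. Its nearest neighbour is compound 1, which lies lower by a gap beyond the scatter; its furthest is compound 2, which lies higher by a gap beyond the scatter. No pair of these compounds differs in a single place, so no step between measured compounds is available.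

Compound 4, `CCN(Cc1ccccn1)c1cccc(C(=O)N2CCc3ccc(OS(N)(=O)=O)cc3C2)c1`, has not yet been measured in this assay. Relative to compound 3 the change is ethyl((pyridin-2-yl)methyl)amino in place of methyl(3-(piperidin-1-yl)propyl)amino on an aromatic carbon. The chain carrying a six-membered non-aromatic ring with 1 hetero atom gives way to a shorter group carrying a six-membered aromatic ring with 1 hetero atom, with no change in hydrogen-bond donors or acceptors.

An upward step is expected, beyond the scatter, because compound 2 gives 66.9% while compound 3 gives 24.1%, and compound 4 carries an aromatic ring on the amine as compound 2 does. The expected step is a number 25.9 percentage points higher from compound 3 to compound 4 (beyond the scatter). Compound 4 is estimated at 50%, within 25% to 75%.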

Compound 4, a percentage reported as inhibition, at one concentration (the size of the read-out at that concentration, not a potency): 6.5%
Beside the measured number, compound 4's estimate is 43.5 percentage points above it; the whole stated range lies above it.
By their numbers in this assay, from the lowest: compounds 1 and 4 (each within the scatter of the next); then compound 3; then compound 2.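

Among these compounds, the step of a number 17.6 percentage points lower from compound 3 to compound 4 (beyond the scatter) gives the first direct reading at this place, on an aromatic carbon meta to a large group, in this assay. The read-out here responds to the identity of the amine substituent, even though the hydrogen-bond donor and acceptor counts of the two groups are the same and their heavy-atom counts are close: ethyl((pyridin-2-yl)methyl)amino stands lower than methyl(3-(piperidin-1-yl)propyl)amino, so an aromatic ring on a shorter group brings no gain at this place in this pair. Nothing available accounts for the drop, so the step stands as an observation without an explanation.

With a single pair at this place, the part played by the ring nitrogen, the ring type and the chain length cannot be separated, and each read-out is a single-concentration value rather than a potency. A plain phenyl ring on the same ethyl-substituted amine, or a morpholine ring at the end of the propyl chain of compound 3, would show which of these parts carries the change.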